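A second tert-butyl on the aryl urea of compound 2

The source may report more compounds than this note shows. Statements on the series, on what has been measured and on what is new or still open speak of the compounds shown alone.

Three ureas share one core and differ in a single group on one aromatic ring. Compound 1 `Cc1ccccc1NC(=O)N[C@@H](C)c1ccccc1` carries a methyl there, compound 2 `C[C@H](NC(=O)Nc1ccccc1C(C)(C)C)c1ccccc1` a tert-butyl, and compound 3 `C[C@H](NC(=O)Nc1ccccc1F)c1ccccc1` a fluoro. In an ADME assay on the whole organism with Oryza sativa as the target, tested at 10 uM (a lower number here means a stronger effect, a higher number a weaker effect of the compound at the concentration tested), compound 1 gives 99%, compound 2 gives 100% and compound 3 gives 65%. Compound 2 has the highest of the three numbers, but the step of a number 1 percentage points higher from compound 1 to compound 2 (within the scatter) is within the scatter, whereas the step of a number 35 percentage points lower from compound 2 to compound 3 (beyond the scatter) is large, and a number 34 percentage points lower from compound 1 to compound 3 (beyond the scatter) points the same way.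

Compound 4 `C[C@H](NC(=O)Nc1cc(C(C)(C)C)ccc1C(C)(C)C)c1ccccc1` has not yet been measured. It differs from compound 2 by tert-butyl in place of hydrogen on an aromatic carbon. Of the measured steps only a number 1 percentage points higher from compound 1 to compound 2 (within the scatter) concerns a tert-butyl entering the ring, and that step stayed within the scatter. Among the measured compounds shown here, no measured step concerns a group entering this place, and the number of compound 2 already sits at the top of what this assay can report, so little room remains upward. The account therefore expects no step beyond the scatter, a number 4 percentage points lower from compound 2 to compound 4 (within the scatter). For compound 4 in this assay it estimates 96%, with a range from 84% to 100%.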

Compound 4, a percentage reported as activity, at one concentration (the size of the read-out at that concentration, not a potency): 97%
Beside the measured number, compound 4's estimate is 1 percentage points below it; the measured number falls inside the stated range.
By their numbers in this assay, from the lowest: compound 3; then compounds 4, 1 and 2 (each within the scatter of the next).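

In this assay, among the compounds shown here, tert-butyl in place of hydrogen on this aromatic carbon, para to a tert-butyl group, gives a number 3 percentage points lower from compound 2 to compound 4 (within the scatter), the first reading at a second place on the ring, and it shows that this ring carries a further group of 4 heavy atoms with no change beyond the scatter. This addition therefore produces no drop like the ones seen so far, which remain the two steps to the fluoro of compound 3, although compound 2 starts so near the top of what the assay reports that only a drop could have shown clearly. Nothing in the data offers an explanation for this result.

The compounds shown leave open whether an amine or a carboxylic acid on this same carbon would lower the number, since tert-butyl is the only group seen here. For the compounds shown here, they also leave open whether a tert-butyl at this place would change the number of compound 3, the one compound of this set with clear room to rise.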